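Fluoro for chloro on the anilide ring of the thione amides

The source may hold more compounds than are shown below. What is called first, only, known or untested is meant among the compounds shown, and "the series" means these compounds.

Compound 2 `CC1=C(C(=O)Nc2ccc(Cl)c(Cl)c2)C(c2ccccc2Cl)NC(=S)N1` is the reference point of the set; in a functional assay on SF-268 cells (Homo sapiens) for cytotoxicity, read by sulforhodamine B assay, with a stated time of 48 h (on this read-out higher numbers stand for weaker inhibition of growth and lower numbers for stronger inhibition of growth), compound 2 gives 8910 nM. Compound 1 `CC1=C(C(=O)Nc2ccc(F)c(Cl)c2)C(c2ccccc2Cl)NC(=S)N1` carries one change against it, (fluoro in place of chloro on an aromatic carbon), and in this assay compound 1 gives 14800 nM. The step is a 1.7-fold higher number from compound 2 to compound 1 (0.22 log units; within the scatter). Compound 3 `COc1cccc(C2NC(=S)NC(C)=C2C(=O)Nc2ccc(Cl)c(Cl)c2)c1` has a different core; the difference to compound 2 is 3-methoxyphenyl in place of 2-chlorophenyl on a saturated ring carbon. In this assay compound 3 gives 12600 nM. The step is a 1.4-fold higher number from compound 2 to compound 3 (0.15 log units; within the scatter). Compound 3 therefore sits with the other two inside the usual scatter, and no ordering among compounds 1, 2 and 3 can be claimed.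

Compound 4 `COc1cccc(C2NC(=S)NC(C)=C2C(=O)Nc2ccc(F)c(Cl)c2)c1` has not yet been measured in this assay. Within the data shown here, it differs from compound 3 by fluoro in place of chloro on an aromatic carbon, the same change as the one from compound 2 to compound 1; the surroundings of the place are described in the same words for both pairs, so the change is the same, only the core on the saturated ring carbon differs. Among the measured compounds shown here, the step from compound 3 to compound 4 is expected to be a 1.5-fold higher number from compound 3 to compound 4 (0.18 log units; within the scatter), resting on the single earlier instance of the change, which gave a 1.7-fold higher number from compound 2 to compound 1 (0.22 log units; within the scatter), and on the fact that the core change itself left the number within scatter, as a 1.4-fold higher number from compound 2 to compound 3 (0.15 log units; within the scatter) shows. Compound 4 is thus estimated at 19000 nM in this assay, with a range from 9000 nM to 40000 nM; whether this holds awaits the measurement.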

Compound 4, concentration for 50% growth inhibition: 18200 nM
Beside the measured number, compound 4's estimate is 1.0-fold (0.02 log units) above it; measured number inside the range.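

In this assay, fluoro in place of chloro on the 3,4-dichlorophenyl group of the anilide gives a 1.4-fold higher number from compound 3 to compound 4 (0.16 log units; within the scatter), and this step agrees with the earlier instance on the core of compound 2: the same change on two cores in this assay, a 1.7-fold higher number (0.22 log units; within the scatter) from compound 2 to compound 1 and a 1.4-fold higher number (0.16 log units; within the scatter) from compound 3 to compound 4, 1.1-fold (0.06 log units) apart, within the scatter of two such steps

The other change, 3-methoxyphenyl in place of 2-chlorophenyl on the saturated ring carbon, is read here with the 3-chloro-4-fluorophenyl amide as a 1.2-fold higher number from compound 1 to compound 4 (0.09 log units; within the scatter), and it agrees with its counterpart in the same way: the same change on two cores in this assay, a 1.4-fold higher number (0.15 log units; within the scatter) from compound 2 to compound 3 and a 1.2-fold higher number (0.09 log units; within the scatter) from compound 1 to compound 4, 1.1-fold (0.06 log units) apart, within the scatter of two such steps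

Across these four compounds, each change therefore carried from one core to the other without a detectable difference, but every step lies within the scatter, so neither change is shown to have any effect of its own, and agreement between such small steps is weak evidence that a larger effect would also carry over, with only two cores behind it.

The compounds shown stay within chloro and fluoro on the anilide ring and within 2-chlorophenyl and 3-methoxyphenyl on the saturated ring carbon. From the compounds shown here alone, whether the additivity still holds for a step beyond the scatter remains open, for example with a nitrile or a trifluoromethyl group on the anilide ring, or a carboxylic acid or an amine on the other aryl group.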